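The compounds below may be only part of what the source reports. "The series", "measured", "known", "first", "only" and "open" are said of these compounds alone.

For the measured compounds named here, in an ADME assay on Vero cells (Chlorocebus sabaeus) for cytotoxicity, read by MTT assay, with a stated time of 72 h (on this read-out higher numbers stand for lower toxicity in this test and lower numbers for higher toxicity in this test), compound 1 `COc1ccccc1[C@H](O)COC(=O)/C=C/c1ccccc1` gives 14000 nM, the lower of the two numbers so far. Compound 2 `COc1ccccc1[C@@H](O)COC(=O)/C=C/c1ccccc1` gives 51700 nM. Going by the values given here, the one measured step, a 3.7-fold higher number from compound 1 to compound 2 (0.57 log units; beyond the scatter), is modest but beyond the scatter, and it comes with the fact that compounds 1 and 2 differ only in the configuration as drawn. It therefore bears only indirectly on a change of substituent and serves here as a rough yardstick of size. Compound 3 `COc1cccc([C@H](O)COC(=O)/C=C/c2ccccc2)c1OC` differs from compound 1 by methoxy in place of hydrogen on an aromatic carbon, ortho to a methoxy group and meta to a large group. Among the compounds with values here, no measured step covers this kind of change, so no direction is favoured in this assay, and no step beyond the scatter is expected. The expected step is a 1.1-fold higher number from compound 1 to compound 3 (0.03 log units; within the scatter). The estimated value for compound 3 is 15000 nM, with an expected range of 6000 nM to 40000 nM.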

Compound 3, half-maximal cytotoxic concentration: 28400 nM
For compound 3 the middle estimate is 1.9-fold (0.28 log units) below the measured one; measured number inside the range.
By their numbers in this assay, from the lowest: compound 1; then compounds 3 and 2 (each within the scatter of the next).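

Methoxy in place of hydrogen on an aromatic carbon, ortho to a methoxy group and meta to a large group, gives in this assay the first measured step for a change of substituent, a 2.0-fold higher number from compound 1 to compound 3 (0.31 log units; beyond the scatter), which points towards lower toxicity in this test at this position. That step is modest and of the same printed grade as the change of configuration alone, a 3.7-fold higher number from compound 1 to compound 2 (0.57 log units; beyond the scatter), so neither change yet stands out from the other in kind of effect. The data at hand give no reason for the step from the added methoxy.

Open, from the compounds shown here alone, is whether another group at this place, such as a hydroxyl, an amine or a carboxylic acid, would move the number the same way. Also open, going by these compounds, is whether the added methoxy gives a step of like size on the configuration of compound 2.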